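Adding an Amino Link: What Compound 4 Might Show

The source may hold more compounds than are shown below. What is called first, only, known or untested is meant among the compounds shown, and "the series" means these compounds.

Of the compounds shown here, three have been tested in a functional assay on A549 cells (Homo sapiens) for inhibition, read by sulforhodamine B assay, with a stated time of 48 h; a higher number here means a weaker inhibitor of growth, a lower number a stronger inhibitor of growth. Compound 1 `COc1cc(-c2nn(-c3cccc(NC(=O)c4ccc(Cl)c(C(F)(F)F)c4)c3)cc2-c2ccncc2)ccc1Cl` gives 2400 nM, compound 2 `COc1cc(-c2nn(-c3cccc(NC(=O)c4cccc(C(F)(F)F)c4)c3)cc2-c2ccncc2)ccc1Cl` gives 1870 nM, and compound 3 `O=C(Nc1cccc(-n2cc(-c3ccncc3)c(-c3ccc(Cl)c(O)c3)n2)c1)Nc1cc(C(F)(F)F)cc(C(F)(F)F)c1` gives 298 nM. Compound 2 thus stands second highest of the three numbers, close to compound 1 and far from compound 3. Going by the values given here, the only single-site step measured, a 1.3-fold lower number from compound 1 to compound 2 (0.11 log units; within the scatter), lies within the scatter. Compound 4 `COc1cc(-c2nn(-c3cccc(NC(=O)Nc4cccc(C(F)(F)F)c4)c3)cc2-c2ccncc2)ccc1Cl` differs from compound 2 by one change: (3-(trifluoromethyl)phenyl)amino in place of 3-(trifluoromethyl)phenyl on a carbonyl carbon. Among the compounds with values here, no measured step probes exactly this change; compound 3 also bears an amino group on its carbonyl carbon and shows a lower number than compound 2, but it differs from compound 2 in more than one place. A modest move toward a lower number is expected, so compound 4 is estimated at 1000 nM, with a range of 350 nM to 2800 nM, meaning a step of a 1.9-fold lower number from compound 2 to compound 4 (0.27 log units; within the scatter).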

Compound 4, concentration for 50% growth inhibition: 794 nM
Compound 4: middle estimate off by 1.3-fold (0.10 log units), on the high side; measured number inside the range.
By their numbers in this assay, from the lowest: compound 3; then compound 4; then compounds 2 and 1 (each within the scatter of the next).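

Going by these compounds alone, putting (3-(trifluoromethyl)phenyl)amino in place of 3-(trifluoromethyl)phenyl on the carbonyl carbon gives a 2.4-fold lower number from compound 2 to compound 4 (0.37 log units; beyond the scatter) in this assay and is the first single-site step here to pass beyond the scatter. The same group replacing 4-chloro-3-(trifluoromethyl)phenyl gives a 3.0-fold lower number from compound 1 to compound 4 (0.48 log units; beyond the scatter) as well, so this position responds to the change. Nothing measured here explains why the number falls. Going by these compounds, it remains open whether the amino hydrogen matters, which an N-methylamino group on the same carbonyl carbon would test, and whether a longer chain there would be tolerated.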